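Furan-3-yl to thiophen-3-yl: notes on compound 3

This account rests on a few compounds, and the source may have more. Where it says the series, first, only, none or still open, it means among the compounds named here.

Within the data shown here, in a functional assay on HL-60 cells (Homo sapiens) for antiproliferative activity, read by XTT assay, with a stated time of 72 h (on this read-out lower numbers stand for stronger inhibition and higher numbers for weaker inhibition), compound 2 (`CN(C)c1ncnc2c1c(-c1ccoc1)cn2[C@@H]1O[C@H](CO)[C@@H](O)[C@H]1O`) gives 1160 nM, the lower of the two numbers so far. Compound 1 (`CSc1ncnc2c1c(-c1ccsc1)cn2[C@@H]1O[C@H](CO)[C@@H](O)[C@H]1O`) gives 4590 nM, and this gap lies beyond the scatter. Compound 3 (`CN(C)c1ncnc2c1c(-c1ccsc1)cn2[C@@H]1O[C@H](CO)[C@@H](O)[C@H]1O`) has thiophen-3-yl in place of furan-3-yl on an aromatic carbon, with the rest of compound 2 unchanged. Among the measured compounds shown here, no measured pair isolates this swap. For the measured compounds named here, compound 1 also bears thiophen-3-yl, but it differs from compound 3 elsewhere on the shared core, so its value sets no size for the step. With so little data, no change beyond the scatter is expected in this assay, and no firm direction can be given. The estimated step is a 1.3-fold higher number from compound 2 to compound 3 (0.11 log units; within the scatter). For compound 3, the expected value is 1500 nM, with an estimated range of 500 nM to 4500 nM.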

Compound 3, half-maximal inhibitory concentration: 1920 nM
The estimate for compound 3 lay 1.3-fold (0.11 log units) below the measured number; the range from low to high includes it.
By their numbers in this assay, from the lowest: compounds 2 and 3 (each within the scatter of the next); then compound 1.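

In this assay, thiophen-3-yl in place of furan-3-yl on an aromatic carbon gives a 1.7-fold higher number from compound 2 to compound 3 (0.22 log units; within the scatter), so the measured pair does not separate these two groups at this position. Among these compounds, the shared thiophen-3-yl also isolates a second place for the first time: dimethylamino in place of methylsulfanyl on an aromatic carbon gives a 2.4-fold lower number from compound 1 to compound 3 (0.38 log units; beyond the scatter), a modest step that is distinguishable from the scatter. No available evidence bears on either result.

Still open, going by these compounds, is whether phenyl or a saturated ring such as cyclopentyl at the same aromatic carbon would depart from the two five-membered aromatic rings. On these data alone, it is also open whether a primary amine or methoxy in place of dimethylamino would change the number, and whether the furan-3-yl to thiophen-3-yl step stays this small with methylsulfanyl on the shared core.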